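Trifluoromethyl for Chloro: From Compound 2 to Compound 3

The compounds below may be only part of what the source reports. "The series", "measured", "known", "first", "only" and "open" are said of these compounds alone.

compound 1 `COc1cccc(N(C)/C(S)=C2/C(=O)c3cc(Cl)ccc3N(C)C2=O)c1` — 30%
compound 2 `CN1C(=O)/C(=C(/S)N(C)c2cccc(Cl)c2)C(=O)c2cc(Cl)ccc21` — 63%

In a functional assay on the whole organism for inhibition, with Mus musculus as the target, at a dose of 10 mg/kg by the oral route (on this read-out higher numbers stand for more inhibition at the one dose given (going by the name of the read-out) and lower numbers for less inhibition), compound 1 gives 30% and compound 2 gives 63%. Going by the values given here, compound 2 stands highest of the two numbers; the only measured step, a number 33 percentage points higher from compound 1 to compound 2 (beyond the scatter), lies beyond the scatter, so the place where the aromatic substituent sits is one where a change of group has mattered. Compound 3 `CN1C(=O)/C(=C(/S)N(C)c2cccc(C(F)(F)F)c2)C(=O)c2cc(Cl)ccc21` differs from compound 2 by trifluoromethyl in place of chloro on an aromatic carbon. Among the compounds with values here, no measured step exchanges chloro for trifluoromethyl, so the step from compound 1 to compound 2 bears on it only in showing that this position is responsive; it does not tell the direction. With compound 2 as the sole anchor, the expected step in this assay is small, most likely not beyond the scatter, with some chance of a loss. Compound 3 is therefore estimated at 55%, with a range from 30% to 80%, a step of a number 8 percentage points lower from compound 2 to compound 3 (within the scatter).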

Compound 3, a percentage reported as inhibition, in the whole organism at one dose (the size of the read-out at that dose, not a potency): 29%
Compound 3: middle estimate off by 26 percentage points, on the high side; the measured number lies below the stated range.
By their numbers in this assay, from the lowest: compounds 3 and 1 (each within the scatter of the next); then compound 2.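

In this assay the exchange of chloro for trifluoromethyl on this aromatic carbon gives a number 34 percentage points lower from compound 2 to compound 3 (beyond the scatter) and so shows that the position responds to more than the change from methoxy. Trifluoromethyl and methoxy cannot be told apart on this read-out, with a number 1 percentage points lower from compound 1 to compound 3 (within the scatter) as the step between them, and chloro is the only one of the three groups whose compound stands clear of the other two. No measurement shown here bears on why chloro differs from both groups.

The compounds shown leave open whether another halogen, such as fluoro or bromo, on the same carbon would keep the number of compound 2, and how an amine or a carboxylic acid there would fare. They also leave open whether the same order of groups would hold at other places on the shared core.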